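Phenylsulfonyl in Place of a Triazinedione Thioether

A few compounds are considered here, and "the series" means these few. Any claim that something is new, unique, unknown or untested is made for them only; others in the source may bear on it.

Within the data shown here, in a physicochemical assay, at pH 7.4 (on this read-out lower numbers stand for a shorter-lived compound and higher numbers for a longer-lived compound), compound 2 `CO[C@H]1C(=O)N2C(C(=O)C(C)(C)C)=C(C)[C@@H](Sc3nc(=O)c(=O)[nH]n3C)S(=O)(=O)C12` gives 21 h, the top of the three numbers measured so far. Compound 1 `CO[C@H]1C(=O)N2C(C(=O)C(C)(C)C)=C(COC(C)=O)CS(=O)(=O)C12` gives 14 h, which lies within the usual scatter of that result, whereas compound 3 `CO[C@H]1C(=O)N2C(C(=O)OC(C)(C)C)=C(C)[C@@H](Sc3ccccn3)S(=O)(=O)C12` gives 4.1 h, a gap beyond the scatter. Compound 4 `CO[C@H]1C(=O)N2C(C(=O)C(C)(C)C)=C(C)[C@@H](S(=O)(=O)c3ccccc3)S(=O)(=O)C12` differs from compound 2 in one place: a group of 9 heavy atoms (6 carbon, 2 oxygen, 1 sulfur; one six-membered aromatic ring of carbon only) in place of a group of 10 heavy atoms (4 carbon, 3 nitrogen, 2 oxygen, 1 sulfur; one six-membered aromatic ring with 3 hetero atoms), on a saturated ring carbon. Among the measured compounds shown here, no measured pair shows this change on its own, and compound 3 differs from compound 2 in two places at once, so there is no single step to lean on. A modest downward step from compound 2 to compound 4 is expected, a 1.9-fold lower number from compound 2 to compound 4 (0.28 log units; within the scatter), one that may still fall within the scatter. For compound 4 in this assay the estimate is 11 h, with a range from 4.5 h to 27 h.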

Compound 4, half-life: 10 h
Compound 4: the middle estimate sits 1.1-fold (0.04 log units) above what was measured; the range from low to high includes it.
By their numbers in this assay, from the lowest: compound 3; then compounds 4, 1 and 2 (each within the scatter of the next, the first and the last beyond it).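

Among these compounds, on this saturated ring carbon, putting phenylsulfonyl in place of the triazinedione thioether gives the first single-place step at this position, a 2.1-fold lower number from compound 2 to compound 4 (0.32 log units; beyond the scatter) in this assay. This shows that the group on this carbon can move the half-life by slightly more than the usual scatter. No measurement available here explains the shift. Going by these compounds, the sulfur link and the aromatic ring change together, so it remains open which of them matters; a phenylthio group on this carbon would separate the two. On these data alone, how an amine there would behave also remains open.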